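Swapping the Aryl Group on a Shared Core

The source may report more compounds than this note shows. Statements on the series, on what has been measured and on what is new or still open speak of the compounds shown alone.

Two compounds share one core. In a functional assay on BJAB cells (Homo sapiens) for antiproliferative activity, with a stated time of 4 days (a lower number here means that less compound is needed, a higher number that more compound is needed for the effect), compound 1 `Cc1cccc(-c2c(C)nn(-c3nc(-c4ccc(Cl)c(Cl)c4)c(SC(C)C)s3)c2C(=O)O)c1` gives 17000 nM, and compound 2 `COc1cc(C#N)cc(-c2c(C)nn(-c3nc(-c4ccc(Cl)c(Cl)c4)c(SC(C)C)s3)c2C(=O)O)c1` gives 5200 nM, the lower of the two numbers; the step of a 3.3-fold lower number from compound 1 to compound 2 (0.51 log units; beyond the scatter) is modest. Compound 3 `CNc1cc(-c2c(C)nn(-c3nc(-c4ccc(Cl)c(Cl)c4)c(SC(C)C)s3)c2C(=O)O)ccn1` carries 2-(methylamino)pyridin-4-yl in place of 3-cyano-5-methoxyphenyl on an aromatic carbon. Within the data shown here, only the step from compound 1 to compound 2 bears on this change, and only loosely: no measured pair carries a pyridine ring. The expected step of a 1.2-fold lower number from compound 2 to compound 3 (0.06 log units; within the scatter) is therefore small and uncertain. Compound 3 is estimated at 4500 nM in this assay, with a range from 1200 nM to 16000 nM.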

Compound 3, half-maximal effective concentration: 18000 nM
Estimate against measurement, compound 3: 4.0-fold (0.60 log units) below, outside the stated range (above it).
By their numbers in this assay, from the lowest: compound 2; then compounds 1 and 3 (each within the scatter of the next).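

In this assay, 2-(methylamino)pyridin-4-yl at this position does not hold the lower number seen with 3-cyano-5-methoxyphenyl, giving a 3.5-fold higher number from compound 2 to compound 3 (0.54 log units; beyond the scatter) and showing that a change of aryl group here can move the number in either direction. Against 3-methylphenyl, the same group gives a 1.1-fold higher number from compound 1 to compound 3 (0.02 log units; within the scatter) and so leaves only compound 2 apart from the other two. No measurement on hand explains this difference.

On these data alone, it remains open whether the ring nitrogen or the methylamino group goes with the higher number. Plain pyridin-4-yl and 3-cyanophenyl would help separate these parts.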